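Working notes: methoxy in place of dimethylamino

The source may hold more compounds than are shown below. What is called first, only, known or untested is meant among the compounds shown, and "the series" means these compounds.

Measured in a toxicity assay on Huh-7.5 cells (Homo sapiens) for inhibition, read by MTT assay, with a stated time of 96 h; a higher number here means that more compound is tolerated, a lower number that less compound is tolerated:
Compound 1 `COc1ccc(NC(=O)c2ccc(OCCCN(C)C)c([N+](=O)[O-])c2)cc1`: 127000 nM
Compound 2 `CC(C)Oc1ccc(C(=O)Nc2ccc(N(C)C)cc2)cc1[N+](=O)[O-]`: 50000 nM

Compound 2 holds the lower of the two numbers, and its gap to compound 1 lies beyond the scatter. Compound 3 `COc1ccc(NC(=O)c2ccc(OC(C)C)c([N+](=O)[O-])c2)cc1` departs from compound 2 by one change, methoxy in place of dimethylamino on an aromatic carbon. Among the compounds with values here, no measured pair isolates this change. Compound 3 shares methoxy with compound 1, which gives 127000 nM, so a modest upward move in this assay is expected, possibly within the scatter. The estimated step is a 1.6-fold higher number from compound 2 to compound 3 (0.20 log units; within the scatter). For compound 3 the expected value is 80000 nM, with an estimated range of 30000 nM to 200000 nM.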

Compound 3, half-maximal cytotoxic concentration: 23400 nM
Compound 3: middle estimate off by 3.4-fold (0.53 log units), on the high side, and the stated range ends above it.
By their numbers in this assay, from the lowest: compound 3; then compound 2; then compound 1.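

In this assay, methoxy in place of dimethylamino on an aromatic carbon gives a 2.1-fold lower number from compound 2 to compound 3 (0.33 log units; beyond the scatter), so this position affects the number and methoxy does not by itself bring the high number of compound 1. Isopropyl in place of 3-(dimethylamino)propyl on an oxygen on an aromatic ring gives a 5.4-fold lower number from compound 1 to compound 3 (0.73 log units; beyond the scatter), so within this pair the higher number goes with the 3-(dimethylamino)propyl chain. No available evidence accounts for either step.

Open, as far as these compounds go, is how a primary amine or a carboxylic acid on that aromatic carbon would read. Also open, from the compounds shown here alone, is how a shorter or longer amine chain on the oxygen would read.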